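A New Aromatic End for Compound 1

The source may hold more compounds than are shown below. What is called first, only, known or untested is meant among the compounds shown, and "the series" means these compounds.

Among the compounds with values here, in a functional assay on MDA-MB-231 cells (Homo sapiens) for inhibition, read by MTT assay (on this read-out higher numbers stand for weaker inhibition of growth and lower numbers for stronger inhibition of growth), compound 1 `CC1=C(/C=C/C(C)=C/C=C/C(C)=C\C(=O)NCc2cccc(F)c2)C(C)(C)CCC1n1ccnc1` gives 1650 nM, the lower of the two numbers so far. Compound 2 `CC1=C(/C=C/C(C)=C/C=C/C(C)=C\C(=O)Nc2ccccc2)C(C)(C)CC=C1c1cncnc1` differs from compound 1 in several places. In this assay, compound 2 gives 26900 nM, and the gap between the two numbers lies beyond the scatter. Compound 3 `CC1=C(/C=C/C(C)=C/C=C/C(C)=C\C(=O)NCc2ccc(O)cc2)C(C)(C)CCC1n1ccnc1` keeps the rest of compound 1 but carries 4-hydroxyphenyl in place of 3-fluorophenyl on a saturated chain carbon bound to an amide-type nitrogen. Within the data shown here, no measured pair shows this kind of change, so the expectation is uncertain. A modest step toward weaker inhibition of growth is expected in this assay, estimated as a 2.4-fold higher number from compound 1 to compound 3 (0.38 log units; beyond the scatter). Compound 3 is expected at 4000 nM, within an estimated range of 1200 nM to 12000 nM.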

Compound 3, concentration for 50% growth inhibition: 2230 nM
Compound 3: middle estimate off by 1.8-fold (0.25 log units), on the high side; measured number inside the range.
By their numbers in this assay, from the lowest: compounds 1 and 3 (each within the scatter of the next); then compound 2.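

In this assay, 4-hydroxyphenyl in place of 3-fluorophenyl on a saturated chain carbon bound to an amide-type nitrogen gives a 1.4-fold higher number from compound 1 to compound 3 (0.13 log units; within the scatter), so this swap leaves the number unchanged within the usual scatter. The entering group adds a hydrogen-bond donor and acceptor, and the two compounds still cannot be told apart here. No measured evidence offers a reason for this result. Still open, as far as these compounds go, is whether 4-aminophenyl or 4-carboxyphenyl in the same place, or a longer chain carrying the ring, would also leave the number unchanged.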